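This account rests on a few compounds, and the source may have more. Where it says the series, first, only, none or still open, it means among the compounds named here.

In an ADME assay on CCRF-CEM cells (Homo sapiens) for antiproliferative activity, with a stated time of 48 h (on this read-out higher numbers stand for weaker inhibition and lower numbers for stronger inhibition), compound 1 `C=C(Br)C(=O)Nc1ccc(/C=C/C(=O)c2ccccc2)cc1` gives 4000 nM while compound 2 `C=C(Br)C(=O)Nc1ccc(/C=C/C(=O)c2ccc(Br)cc2)cc1` gives 990 nM and compound 3 `C=C(Br)C(=O)Nc1ccc(/C=C/C(=O)c2ccc(C)cc2)cc1` gives 1800 nM on the same read-out. Compound 2 thus sits well under compound 1, yet a 1.8-fold higher number from compound 2 to compound 3 (0.26 log units; within the scatter) is no real separation. Compound 4 `C=C(Br)C(=O)Nc1ccc(/C=C/C(=O)c2cccc(OC)c2)cc1` has not been measured. Compared with compound 2 it carries 3-methoxyphenyl in place of 4-bromophenyl on a carbonyl carbon. For the measured compounds named here, two measured steps bear on this change: a 4.0-fold lower number from compound 1 to compound 2 (0.61 log units; beyond the scatter) and a 2.2-fold lower number from compound 1 to compound 3 (0.35 log units; beyond the scatter) are both modest. Neither involves a methoxy group, so the evidence is only indirect. Going by the values given here, the expected change is a 1.8-fold higher number from compound 2 to compound 4 (0.26 log units; within the scatter) and is no larger than those steps. Compound 4 is estimated at 1800 nM (expected range 700 nM to 4500 nM).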

Compound 4, half-maximal inhibitory concentration: 2300 nM
For compound 4 the middle estimate is 1.3-fold (0.11 log units) below the measured one, and the stated range covers the measured number.
By their numbers in this assay, from the lowest: compounds 2, 3, 4 and 1 (each within the scatter of the next, the first and the last beyond it).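

In this assay the swap on this carbonyl carbon gives a 2.3-fold higher number from compound 2 to compound 4 (0.37 log units; beyond the scatter) and so shows that 3-methoxyphenyl does not match 4-bromophenyl here. Against the other groups, the swap gives a 1.3-fold higher number from compound 3 to compound 4 (0.11 log units; within the scatter) and adding methoxy gives a 1.7-fold lower number from compound 1 to compound 4 (0.24 log units; within the scatter) so, unlike bromo and methyl, this methoxy group does not move the number beyond the scatter from compound 1. Nothing measured here gives a cause for this. Still open, from the compounds shown here alone, is whether the group or its place on the ring matters more, which 4-methoxyphenyl or 3-bromophenyl could test. Going by these compounds, how an amine or a carboxylic acid on this ring would read also remains open.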